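Methyl on an Amine Nitrogen: Estimating Compound 4

A few compounds are considered here, and "the series" means these few. Any claim that something is new, unique, unknown or untested is made for them only; others in the source may bear on it.

Measured so far:
Compound 1, `CN(C)c1ncnc2c1ncn2CC1CC1`, gives 4.5 mg/kg.
Compound 2, `CNc1ncnc2c1ncn2CC1CC1`, gives 12 mg/kg.
Compound 3, `Nc1nc(NC2CC2)c2ncn(CC3CC3)c2n1`, gives 9 mg/kg.

All three numbers come from a functional assay on the whole organism for antagonist activity, with Rattus norvegicus as the target; on this read-out lower numbers stand for an effect already at smaller amounts and higher numbers for an effect only at larger amounts of compound. Compound 2 and compound 1 differ in one place, (methyl in place of hydrogen on a nitrogen on an aromatic ring), and this step gave a 2.7-fold lower number from compound 2 to compound 1 (0.43 log units; beyond the scatter). Compound 3 shares only part of its make-up with compound 2; the difference between the two cores is not broken down here, and the two values sit within the scatter of each other.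

Compound 4, `CNc1nc(NC2CC2)c2ncn(CC3CC3)c2n1`, is not yet measured. It differs from compound 3 by methyl in place of hydrogen on a nitrogen on an aromatic ring. Among the compounds with values here, this is the same kind of change as the measured step, though not the same: in the measured pair the nitrogen's other neighbours are an aromatic carbon and a saturated chain carbon, while in the new pair the only other neighbour is an aromatic carbon. A somewhat smaller step is therefore expected, a 1.8-fold lower number from compound 3 to compound 4 (0.26 log units; within the scatter), resting on a 2.7-fold lower number from compound 2 to compound 1 (0.43 log units; beyond the scatter) seen in the earlier pair. In this assay compound 4 is estimated at 5 mg/kg, with a likely range from 2.5 mg/kg to 12 mg/kg.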

Compound 4, dose for half-maximal effect: 3 mg/kg
Estimate against measurement, compound 4: 1.7-fold (0.22 log units) above; low and high end bracket the measured number.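

In this assay, the change from amino to methylamino gave a 3.0-fold lower number from compound 3 to compound 4 (0.48 log units; beyond the scatter). Set beside the earlier pair, the same change kept about the same size on the second core: the same change on two cores in this assay, a 2.7-fold lower number (0.43 log units; beyond the scatter) from compound 2 to compound 1 and a 3.0-fold lower number (0.48 log units; beyond the scatter) from compound 3 to compound 4, 1.1-fold (0.05 log units) apart, within the scatter of two such steps This shows that, for these two pairs, the step carried over from one core to the other, but two pairs cannot show that it would hold on any further core, and they do not explain why it occurs; the two nitrogens also started out differently, since the one in the earlier pair already carried a saturated chain carbon and the one in the new pair had only an aromatic carbon as its other neighbour.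

The compounds shown leave open whether a longer chain, such as ethyl or propyl, on this nitrogen would give a step of similar size. They also leave open how an acetyl group, or a hydroxyethyl chain, in place of the methyl would read in the same test.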